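This account rests on a few compounds, and the source may have more. Where it says the series, first, only, none or still open, it means among the compounds named here.

Among the measured compounds shown here, compound 1, `O=c1c(C2N=C(c3ccccc3)SS2)coc2cc(Cl)c(Cl)cc12`, is the only compound with a proper number in a functional assay on OVCAR-3 cells (Homo sapiens) for inhibition, read by sulforhodamine B assay, with a stated time of 48 h; on this read-out lower numbers stand for stronger inhibition and higher numbers for weaker inhibition: compound 1 gives 65200 nM. Compound 2, `O=c1c(C(=S)Nc2ccccc2)coc2cc(Cl)c(Cl)cc12`, stands at a limit of the assay rather than at a number; in this assay compound 2 gives > 100000 nM. That is the limit of > 100000 nM in this assay, at which 1 of the 2 values shown sits. Compound 3, `O=c1c(C2N=C(c3ccccc3)SS2)coc2cc(Cl)c(F)cc12`, has not yet been measured in this assay. It differs from compound 1 in one place: fluoro in place of chloro on an aromatic carbon. For the measured compounds named here, no measured pair shows the effect of such a change here, and the two existing values offer no guide, since one of them is only a limit. The exchange leaves the counts of heavy atoms, hydrogen-bond donors and acceptors unchanged. The step in this assay is therefore expected to be small, within the usual scatter, leaning if anything toward weaker inhibition. The expected step from compound 1 to compound 3 is a 1.2-fold higher number from compound 1 to compound 3 (0.09 log units; within the scatter). On that basis compound 3 is estimated at 80000 nM in this assay, with a range from 30000 nM to 200000 nM, and with a real chance that only a limit is returned.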

Compound 3, half-maximal inhibitory concentration: 61700 nM
For compound 3 the middle estimate is 1.3-fold (0.11 log units) above the measured one; measured number inside the range.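

Among the compounds shown here, this is the first pair in this assay that differs in one place, and fluoro in place of chloro on an aromatic carbon gives a 1.1-fold lower number from compound 1 to compound 3 (0.02 log units; within the scatter). At this position, ortho to a chloro group, meta to a fused ring and para to a fused ring, the read-out therefore does not separate fluoro from chloro on the core of compound 1, and the exchange shows no change in either direction. Compound 3 also returns a proper number and does not join compound 2, whose value remains a limit: the limit of > 100000 nM in this assay, at which 1 of the 3 values shown sits.

From the compounds shown here alone, what a hydrogen, a methoxy group, an amine or a carboxylic acid would do at this same position remains open, since a single exchange between two halogens does not show how far the position tolerates a different kind of group. Also open, going by these compounds, is whether the same exchange would read the same way on the core of compound 2, or at the position of the remaining chloro group.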